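A few compounds are considered here, and "the series" means these few. Any claim that something is new, unique, unknown or untested is made for them only; others in the source may bear on it.

Of the compounds shown here, three on the shared core have been measured so far. Compound 1 `COc1cc(-c2cc(/C=C/C(=O)c3ccc(N)cc3)[nH]n2)cc(OC)c1OC` gives 1660 nM in a functional assay on MDA-MB-435 cells (Homo sapiens) for inhibition, read by sulforhodamine B assay, with a stated time of 48 h; on this read-out lower numbers stand for stronger inhibition of growth and higher numbers for weaker inhibition of growth. Compound 2 `COc1ccc(-c2cc(/C=C/C(=O)c3cc(OC)c(OC)c(OC)c3)[nH]n2)cc1OC` gives 1780 nM in this assay. Compound 3 `COc1ccc(C(=O)/C=C/c2cc(-c3cc(OC)c(OC)c(OC)c3)n[nH]2)cc1` gives 2200 nM in this assay. Compound 3 carries the highest of the three numbers, yet its gaps to compound 2 and to compound 1 are both within the scatter, so the three stand together rather than in any order. For the measured compounds named here, the only single-point step among them, a 1.3-fold higher number from compound 1 to compound 3 (0.12 log units; within the scatter), is likewise within the scatter.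

Compound 4 `COc1cc(-c2cc(/C=C/C(=O)c3ccc(F)c(F)c3)[nH]n2)cc(OC)c1OC` has not yet been measured. Its structure differs from compound 3 in one place: 3,4-difluorophenyl in place of 4-methoxyphenyl on a carbonyl carbon. Going by the values given here, no measured pair exchanges the group on the carbonyl carbon, so no step bears directly on this change; the only step available, a 1.3-fold higher number from compound 1 to compound 3 (0.12 log units; within the scatter), altered a different part of the same aryl group and produced nothing beyond the scatter. Compound 4 is therefore expected to show a step of a 1.1-fold higher number from compound 3 to compound 4 (0.06 log units; within the scatter) in this assay, that is, none beyond the scatter. Compound 4 is estimated at 2500 nM, within a range from 1000 nM to 6500 nM.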

Compound 4, concentration for 50% growth inhibition: 2880 nM
Compound 4: the middle estimate sits 1.2-fold (0.06 log units) below what was measured; measured number inside the range.
By their numbers in this assay, from the lowest: compounds 1, 2, 3 and 4 (each within the scatter of the next).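

For the compounds shown here, this is the first outright exchange of the whole aryl group on the carbonyl carbon: 3,4-difluorophenyl in place of 4-methoxyphenyl gives a 1.3-fold higher number from compound 3 to compound 4 (0.12 log units; within the scatter) in this assay and 3,4-difluorophenyl in place of 4-aminophenyl gives a 1.7-fold higher number from compound 1 to compound 4 (0.24 log units; within the scatter) on the same read-out. The three aryl groups therefore stand together at this place, including 3,4-difluorophenyl, which has no hydrogen-bond acceptor counted on it while 4-methoxyphenyl has. Nothing measured alongside these numbers gives a reason for the absence of a separation.

As far as these compounds go, every step on this group so far lies within the scatter, so it is open whether any replacement on the carbonyl carbon can move the number beyond it. A carboxylic acid, a morpholine or a non-aromatic alkyl chain at this place would test that.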